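The source may hold more compounds than are shown below. What is called first, only, known or untested is meant among the compounds shown, and "the series" means these compounds.

Compounds measured so far in a functional assay on A-375 cells (Homo sapiens) for cytotoxicity, read by MTT assay; a lower number here means a stronger inhibitor, a higher number a weaker inhibitor:
- compound 1 `O=S(=O)(NCCCNc1nccc(-c2c(-c3cccc(F)c3)nc3sccn23)n1)c1ccc(F)cc1`: 14500 nM
- compound 2 `O=C(NCCNc1nccc(-c2c(-c3cccc(F)c3)nc3sccn23)n1)c1c(F)cccc1F`: 2700 nM
- compound 3 `O=C(NCCNc1nccc(-c2c(-c3cccc(F)c3)nc3sccn23)n1)c1ccccc1`: 5060 nM

Compound 3 holds the second highest of the three numbers. Its nearest neighbour is compound 2, reached by a 1.9-fold higher number from compound 2 to compound 3 (0.27 log units; within the scatter), a gap that stays within the scatter; compound 1 lies further off, with a 2.9-fold lower number from compound 1 to compound 3 (0.46 log units; beyond the scatter).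

Compound 4 `Cc1ccc(C(=O)NCCNc2nccc(-c3c(-c4cccc(F)c4)nc4sccn34)n2)cc1` differs from compound 3 only by methyl in place of hydrogen on an aromatic carbon. Among the measured compounds shown here, no measured step touches this position on that ring. For the measured compounds named here, the one step that alters the same ring at all, a 1.9-fold higher number from compound 2 to compound 3 (0.27 log units; within the scatter), stayed within the scatter even when two fluorines were exchanged, so a single methyl is expected to move this assay by no more than the scatter, as a 1.0-fold lower number from compound 3 to compound 4 (0.01 log units; within the scatter). Compound 4 is therefore estimated at 5000 nM, with a range from 2000 nM to 12000 nM.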

Compound 4, half-maximal inhibitory concentration: 5880 nM
For compound 4 the middle estimate is 1.2-fold (0.07 log units) below the measured one, within the range that was stated.
By their numbers in this assay, from the lowest: compounds 2, 3 and 4 (each within the scatter of the next, the first and the last beyond it); then compound 1.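

In this assay, the first substituent placed para to a large group on this ring, phenyl to 4-methylphenyl, leaves the number within the scatter (a 1.2-fold higher number from compound 3 to compound 4 (0.07 log units; within the scatter)). Compound 4 nevertheless stands beyond the scatter from the 2,6-difluorophenyl amide (a 2.2-fold higher number from compound 2 to compound 4 (0.34 log units; beyond the scatter)), a separation compound 3 did not show, and it also stays apart from the sulfonamide (a 2.5-fold lower number from compound 1 to compound 4 (0.39 log units; beyond the scatter)). No available evidence bears on this result.

As far as these compounds go, whether a methoxy group or a carboxylic acid at this same position would move the number beyond the scatter remains open. So does whether a methyl at another carbon of this ring would behave as this one does.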